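Adding vinylcarbonyl to a growth inhibitor

This account rests on a few compounds, and the source may have more. Where it says the series, first, only, none or still open, it means among the compounds named here.

- Compound 1 `O=C1/C(=C/c2ccc3ccccc3c2)CNC/C1=C\c1ccc2ccccc2c1`: 6800 nM
- Compound 2 `Cc1ccc(/C=C2\CNC/C(=C\c3ccc(C)s3)C2=O)s1`: 80700 nM

In a functional assay on MCF7 cells (Homo sapiens) for antiproliferative activity, read by sulforhodamine B assay, with a stated time of 48 h (a lower number here means a stronger inhibitor of growth, a higher number a weaker inhibitor of growth), compound 1 has the lower of the two numbers, and the gap up to compound 2 lies beyond the usual scatter of repeated measurements. Going by the values given here, compound 1 is therefore the better inhibitor of growth so far, though only two compounds can be compared.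

Compound 3 `C=CC(=O)N1C/C(=C\c2ccc3ccccc3c2)C(=O)/C(=C/c2ccc3ccccc3c2)C1` has not yet been measured. It keeps the core of compound 1 and changes in one place: vinylcarbonyl in place of hydrogen on an amine nitrogen in a ring. Among the compounds with values here, no measured pair shows what this change does, so the expectation is a judgement with a wide range. A moderate move towards a lower number is expected, a 3.8-fold lower number from compound 1 to compound 3 (0.58 log units; beyond the scatter). For compound 3 the estimated value is 1800 nM, with an expected range from 350 nM to 9000 nM.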

Compound 3, concentration for 50% growth inhibition: 1400 nM
Compound 3: middle estimate off by 1.3-fold (0.11 log units), on the high side; the measured number falls inside the stated range.
By their numbers in this assay, from the lowest: compound 3; then compound 1; then compound 2.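

In this assay, vinylcarbonyl in place of hydrogen on an amine nitrogen in a ring gives a 4.9-fold lower number from compound 1 to compound 3 (0.69 log units; beyond the scatter) and so a modest gain that lies beyond the usual scatter. Going by these compounds alone, this is the first single-place step, and it shows that the hydrogen on this nitrogen is not needed for growth inhibition and that a group can be carried there with a gain. Nothing measured here bears on why the number falls.

From the compounds shown here alone, it remains open whether the double bond of vinylcarbonyl matters, which a saturated propanoyl or a smaller acetyl group on the same nitrogen would help to settle. Going by these compounds, it is also open whether the same change would bring a similar gain on the core of compound 2.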